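Methoxy to hydroxy: what should compound 3 do?

The source may hold more compounds than are shown below. What is called first, only, known or untested is meant among the compounds shown, and "the series" means these compounds.

Measured compounds (a functional assay on MCF7 cells (Homo sapiens) for antiproliferative activity, read by sulforhodamine B assay, with a stated time of 48 h; on this read-out higher numbers stand for weaker inhibition and lower numbers for stronger inhibition):
- compound 1 (`COc1ccc(/C=C/C(=O)c2ccccc2-c2ccc(F)cc2)cc1O`): 190 nM
- compound 2 (`COc1ccc(/C=C/C(=O)c2ccccc2-c2cccc(F)c2)cc1OC`): 1200 nM

Compound 2 has the higher of these two numbers, which makes it the weaker inhibitor of the pair. The gap to compound 1 lies beyond the usual scatter. The unmeasured compound 3 (`COc1ccc(/C=C/C(=O)c2ccccc2-c2cccc(F)c2)cc1O`) differs from compound 2 in one place (hydrogen in place of methyl on an oxygen on an aromatic ring): hydrogen in place of methyl on an oxygen on an aromatic ring, or methoxy to hydroxy. Within the data shown here, no measured pair shows this change alone. Compound 1 does carry that hydroxy, although its fluorine sits elsewhere, and in this assay compound 1 gives a low number (190 nM). A move to a lower number, beyond the scatter, is therefore expected (a 4.8-fold lower number from compound 2 to compound 3 (0.68 log units; beyond the scatter)). Compound 3 is estimated at 250 nM (range 80 nM to 800 nM).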

Compound 3, half-maximal inhibitory concentration: 65 nM
The estimate for compound 3 lay 3.8-fold (0.59 log units) above the measured number; the measured number lies below the stated range.
By their numbers in this assay, from the lowest: compound 3; then compound 1; then compound 2.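

In this assay, swapping the methyl on the oxygen for hydrogen, with the rest of the molecule unchanged, gives a large step (an 18-fold lower number from compound 2 to compound 3 (1.27 log units; beyond the scatter)), so this one position strongly affects the read-out in this series. Keeping the hydroxy and changing 4-fluorophenyl to 3-fluorophenyl gives a modest step that is still beyond the scatter (a 2.9-fold lower number from compound 1 to compound 3 (0.47 log units; beyond the scatter)), so the fluorine's place also matters when the hydroxy is present. Nothing in hand explains why either change has the effect it does.

On these data alone, it remains open whether the methoxy to hydroxy step would be as large in a compound carrying 4-fluorophenyl. Also open, as far as these compounds go, is how an amine in place of the hydroxy, or an ethoxy or longer chain on the same oxygen, would compare.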